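Sulfanyl in Place of Chloro on an Inactive Core

A few compounds are considered here, and "the series" means these few. Any claim that something is new, unique, unknown or untested is made for them only; others in the source may bear on it.

Compound 1 `OCCOCn1c(Cl)nc2c(Cl)c(Cl)ccc21` was tested in a functional assay on KB cells (Homo sapiens) for inhibition; on this read-out lower numbers stand for stronger inhibition and higher numbers for weaker inhibition. In this assay compound 1 gives only a limit of the assay, > 100000 nM. Compound 2 `OCCOCn1cnc2cc(Cl)c(Cl)cc21` was tested in the same way. In this assay compound 2 likewise gives only a limit, > 100000 nM. Both values sit at the limit of > 100000 nM in this assay, at which 2 of the 2 values shown sit, so no measured step between the two can be read, and compound 1 stands at the limit alongside the only other compound shown. Compound 3 `OCCOCn1c(S)nc2c(Cl)c(Cl)ccc21` differs from compound 1 in one place: sulfanyl in place of chloro on an aromatic carbon. No measured step of this kind exists among the compounds shown. Compound 3 is expected to show a step of a number no higher from compound 1 to compound 3 (the limit leaves the size open) in this assay, none beyond the usual scatter. Compound 3 is accordingly expected to give 100000 nM, with a range from 30000 nM to 300000 nM, most likely again only a limit.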

Compound 3, half-maximal inhibitory concentration: > 100000 nM
Compound 3: only a limit was reported (the forecaster's own chance of this, stated with the estimate: 80%); the middle value lies on the limit itself.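

In this assay compound 3 gives only a limit, > 100000 nM, and compound 1 also gives only a limit, so no step between the two can be read: the limit of > 100000 nM in this assay, at which 3 of the 3 values shown sit.

The compounds shown leave open whether sulfanyl in place of chloro changes inhibition at all.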